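The source may hold more compounds than are shown below. What is called first, only, known or untested is meant among the compounds shown, and "the series" means these compounds.

In a physicochemical assay for solubility, read by HPLC, using the shake flask method, measured as kinetic solubility, with a stated time of 20 h, at pH 6.5, tested at 200 uM (on this read-out lower numbers stand for lower solubility and higher numbers for higher solubility), compound 1 `CS(=O)(=O)c1cccc(-c2ccc3nccc(-c4ccncc4)c3n2)c1` gives only a limit of the assay, < 5000 nM, and no number. Compound 2 `NS(=O)(=O)c1cccc(-c2ccc3nccc(N4CCN(Cc5ccccc5)CC4)c3n2)c1` also returns only a limit, < 5000 nM. For the measured compounds named here, compound 3 `CS(=O)(=O)c1cccc(-c2ccc3nccc(N4CCNCC4)c3n2)c1` gives 165000 nM, so that the move an at least 33-fold higher number from compound 1 to compound 3 (1.51 log units; beyond the scatter) is the one measured step here, and it alters a different part of the shared core. Compound 4 `CS(=O)(=O)Nc1cccc(-c2ccc3nccc(-c4ccncc4)c3n2)c1` differs from compound 1 by methanesulfonamido in place of methylsulfonyl on an aromatic carbon. Going by the values given here, no measured step touches this group, so nothing among the numbers sets its size; the only guide is the limit of < 5000 nM in this assay, at which 2 of the 3 values shown sit. For compound 4 the expected step is an at least 1.2-fold higher number from compound 1 to compound 4 (0.07 log units; that floor lies within the scatter), kept small for want of evidence either way. Compound 4 is therefore estimated at 6000 nM, within a range from 1000 nM to 30000 nM.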

Compound 4, solubility: 20000 nM
For compound 4 the middle estimate is 3.3-fold (0.52 log units) below the measured one; the range from low to high includes it.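

In this assay, methanesulfonamido in place of methylsulfonyl on an aromatic carbon gives an at least 4.0-fold higher number from compound 1 to compound 4 (0.60 log units; beyond the scatter). This shows that the read-out responds at this position too, and not only where pyridin-4-yl sits in compound 1. The size of the step is only a floor, as compound 1 has a limit and no number: the limit of < 5000 nM in this assay, at which 2 of the 4 values shown sit.

The compounds shown leave open whether an amine or a carboxylic acid at this place would give a higher number. They also leave open whether methanesulfonamido and piperazin-1-yl would add up on the shared core.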